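This account rests on a few compounds, and the source may have more. Where it says the series, first, only, none or still open, it means among the compounds named here.

Measured in an assay on isolated protein for inhibition of Dihydrofolate reductase (Homo sapiens), using NADPH, with a stated time of 5 min; a higher number here means a weaker inhibitor, a lower number a stronger inhibitor:
compound 1 `CCc1nc(N)nc(N)c1C#CC(C)c1ccc(-c2ccccc2)cc1OC` gives 172 nM
compound 2 `CCc1nc(N)nc(N)c1C#CC(C)c1ccc(-c2ccc(O)cc2)cc1OC` gives 136 nM
compound 3 `CCc1nc(N)nc(N)c1C#CC(C)c1ccc(-c2ccc(C(=O)OC)cc2)cc1OC` gives 49 nM

Compound 3 has the lowest number of the three: a 3.5-fold lower number from compound 1 to compound 3 (0.55 log units; beyond the scatter) and a 2.8-fold lower number from compound 2 to compound 3 (0.44 log units; beyond the scatter), both modest and both beyond the scatter. Compound 4 `CCc1nc(N)nc(N)c1C#CC(C)c1ccc(-c2ccc(F)cc2)cc1OC` carries fluoro in place of methoxycarbonyl on an aromatic carbon. Within the data shown here, no measured step exchanges methoxycarbonyl for fluoro; the nearest guides are the two steps into compound 3, where methoxycarbonyl in place of hydrogen or of hydroxy lowered the number. Taking methoxycarbonyl away again is therefore expected to raise the number by roughly the size of those steps, fluoro being a single heavy atom where methoxycarbonyl brought four. Compound 4 is expected at 140 nM, with a range of 70 nM to 280 nM. The expected step is a 2.9-fold higher number from compound 3 to compound 4 (0.46 log units; beyond the scatter) in this assay.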

Compound 4, half-maximal inhibitory concentration: 148 nM
Beside the measured number, compound 4's estimate is 1.1-fold (0.02 log units) below it; measured number inside the range.
By their numbers in this assay, from the lowest: compound 3; then compounds 2, 4 and 1 (each within the scatter of the next).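

In this assay, fluoro on this aromatic carbon does not keep the lower number of compound 3 (a 3.0-fold higher number from compound 3 to compound 4 (0.48 log units; beyond the scatter)), so among the groups shown at this place, that number goes with methoxycarbonyl alone. Fluoro cannot be told apart from hydroxy (a 1.1-fold higher number from compound 2 to compound 4 (0.04 log units; within the scatter)) or from hydrogen (a 1.2-fold lower number from compound 1 to compound 4 (0.07 log units; within the scatter)), which leaves compounds 1, 2 and 4 level. Nothing available here accounts for this difference. Methoxycarbonyl is the only carbonyl-bearing group shown at this place. A carboxylic acid, an amide or a nitrile there would test whether the lower number extends beyond the methyl ester.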